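The compounds below may be only part of what the source reports. "The series", "measured", "known", "first", "only" and "open" are said of these compounds alone.

Measured compounds:
compound 1, `Cc1cccc(NC(=O)Nc2cccc(CNc3ncnc4ccccc34)c2)c1` — in a functional assay on A549 cells (Homo sapiens) for antiproliferative activity, read by MTT assay (on this read-out higher numbers stand for weaker inhibition and lower numbers for stronger inhibition), compound 1 gives 30200 nM
compound 2, `COc1cc2ncnc(NCc3cccc(NC(=O)Nc4ccccc4)c3)c2cc1OC` — in this assay compound 2 gives 17100 nM

Compound 2 has the lower of the two numbers, but the gap to compound 1 lies within the scatter, so the two cannot be told apart. Compound 3, `COc1cc2ncnc(NCc3cccc(NC(=O)Nc4ccc(F)cc4)c3)c2cc1OC`, differs from compound 2 by fluoro in place of hydrogen on an aromatic carbon, a fluoro in place of hydrogen on an aromatic carbon. Going by the values given here, no measured pair shows this change, and a single added fluorine on an outer ring is a small alteration, so no step beyond the scatter is expected. Compound 3 is therefore expected to give about 14000 nM in this assay, between 6000 nM and 35000 nM, which means an expected step of a 1.2-fold lower number from compound 2 to compound 3 (0.09 log units; within the scatter).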

Compound 3, half-maximal inhibitory concentration: 16900 nM
Beside the measured number, compound 3's estimate is 1.2-fold (0.08 log units) below it; the range from low to high includes it.
By their numbers in this assay, from the lowest: compounds 3, 2 and 1 (each within the scatter of the next).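

Swapping hydrogen for fluoro on the outer phenyl ring, para to a large group, gives the first comparison here in which only one place differs: in this assay it is a 1.0-fold lower number from compound 2 to compound 3 (0.01 log units; within the scatter). At this position, then, a single fluoro leaves the number unchanged within the usual variation. Nothing available explains this result.

As far as these compounds go, whether a different group at this position, such as methoxy, trifluoromethyl or an amine, would shift the number remains open. So does whether fluoro would behave the same way on the core of compound 1.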